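Half-life across a short amide side chain

A few compounds are considered here, and "the series" means these few. Any claim that something is new, unique, unknown or untested is made for them only; others in the source may bear on it.

Measured so far in an ADME assay on the whole organism (strain CD1) for metabolic stability, with Mus musculus as the target, read by LC-MS, at a dose of 5 mg/kg by the intravenous route; a lower number here means that the compound disappears faster, a higher number that the compound lasts longer
Compound 1 `Cc1c(Oc2cnc(C(=O)NC(C)CO)cn2)ccc2c1B(O)OC2` with 3.1 h
Compound 2 `CCC[C@H](CO)NC(=O)c1cnc(Oc2ccc3c(c2C)B(O)OC3)cn1` with 4.2 h

On the two numbers available, compound 2 at 4.2 h stands within the scatter of compound 1 at 3.1 h in this measure of how long a compound lasts. Compound 3 `Cc1c(Oc2cnc(C(=O)N[C@@H](CO)CC(F)(F)F)cn2)ccc2c1B(O)OC2` has not yet been measured. Its difference from compound 2 is trifluoromethyl in place of ethyl on a saturated chain carbon, two bonds along the chain from an amide-type nitrogen and places trifluoromethyl in place of ethyl on a saturated chain carbon, two bonds along the chain from an amide-type nitrogen. Within the data shown here, the only measured step in this chain is a 1.4-fold higher number from compound 1 to compound 2 (0.13 log units; within the scatter) and it lies within the scatter. Among the measured compounds shown here, no measured compound carries trifluoromethyl, so the data offer no direct guide. In this assay no step beyond the scatter is therefore expected. The estimated step is a 1.1-fold lower number from compound 2 to compound 3 (0.02 log units; within the scatter) and it stays within the scatter. Compound 3 is expected at 4 h (estimated range 2 h to 8 h).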

Compound 3, half-life: 3 h
Compound 3: middle estimate off by 1.3-fold (0.12 log units), on the high side, and the stated range covers the measured number.
By their numbers in this assay, from the lowest: compounds 3, 1 and 2 (each within the scatter of the next).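

In this assay, among these compounds, the step on trifluoromethyl in place of ethyl is a 1.4-fold lower number from compound 2 to compound 3 (0.15 log units; within the scatter), so the first fluorine-bearing group at this place on the chain stays within the scatter of the ethyl-bearing chain. The wider change, which swaps the whole side chain on the amide-type nitrogen, gives a 1.0-fold lower number from compound 1 to compound 3 (0.01 log units; within the scatter), and this also lies within the scatter, so all three side chains now stand within the scatter of one another. Nothing available explains this result. On these data alone, whether an amine, a carboxylic acid or a longer chain on this saturated chain carbon would carry the half-life beyond the scatter remains open. All three compounds also keep the hydroxymethyl group, so its replacement by a methyl ether or an amide is an open question too.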